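Replacing ethoxy with acetyl on compound 2

A few compounds are considered here, and "the series" means these few. Any claim that something is new, unique, unknown or untested is made for them only; others in the source may bear on it.

Three compounds with a shared core have numbers in a functional assay on HaCaT cells (Homo sapiens) for antiproliferative activity, read by sulforhodamine B assay, with a stated time of 3 days; a higher number here means a weaker inhibitor, a lower number a stronger inhibitor. Compound 1 (`COC(=O)c1cc(CCc2cc(OC(C)=O)ccc2OC(C)=O)ccc1O`) gives 24000 nM, compound 2 (`CCOc1ccc(OC)c(CCc2ccc(O)c(C(=O)OC)c2)c1`) gives 540 nM, and compound 3 (`CCOc1ccc(OCC)c(CCc2ccc(O)c(C(=O)OC)c2)c1`) gives 380 nM. Compound 2 therefore stands level with compound 3, and both lie far under compound 1.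

The compound still to be measured is compound 4 (`COC(=O)c1cc(CCc2cc(C(C)=O)ccc2OC)ccc1O`), which differs from compound 2 in one place: acetyl in place of ethoxy on an aromatic carbon. Acetyl takes the place of ethoxy on an aromatic carbon, para to a methoxy group.

Going by the values given here, only one measured step touches a group of this kind: a 1.4-fold lower number from compound 2 to compound 3 (0.15 log units; within the scatter). There, methyl replaces hydrogen on a saturated chain carbon bound to an oxygen on an aromatic ring. That step stays within the scatter, but it keeps the oxygen on the ring, so it says little about replacing ethoxy with acetyl. The only hint of direction comes from compound 1, which also lacks the ethoxy group and gives 24000 nM, although it differs from compound 2 in more than one place.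

A moderate loss of strength is therefore expected, and the estimated step is a 2.8-fold higher number from compound 2 to compound 4 (0.44 log units; beyond the scatter). For compound 4 the estimate is 1500 nM, with an expected range from 400 nM to 6000 nM.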

Compound 4, half-maximal inhibitory concentration: 660 nM
Estimate against measurement, compound 4: 2.3-fold (0.36 log units) above; measured number inside the range.
By their numbers in this assay, from the lowest: compounds 3, 2 and 4 (each within the scatter of the next); then compound 1.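

In this assay, placing acetyl where ethoxy stood, on an aromatic carbon para to a methoxy group, gives a 1.2-fold higher number from compound 2 to compound 4 (0.09 log units; within the scatter), so the two compounds cannot be told apart. The earlier step, a 1.4-fold lower number from compound 2 to compound 3 (0.15 log units; within the scatter), kept an oxygen on the ring, whereas this one shows that the ring atom here can carry a carbon-linked acetyl in place of an oxygen-linked ethoxy with no change beyond the scatter. The two groups match in the computed counts, each with 3 heavy atoms and 1 hydrogen-bond acceptor, and no measurement offered here explains why the number holds.

These compounds do not show how this position responds to a group that differs more in size or kind, such as an amine, a carboxylic acid or a longer chain. They also leave open which of its changes accounts for the much higher number of compound 1, 24000 nM, which differs from compound 2 in more than one place and so cannot be assigned to any single change.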